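The source may report more compounds than this note shows. Statements on the series, on what has been measured and on what is new or still open speak of the compounds shown alone.

Compound 1 `CCOC(=O)c1c(C)nc(-c2cccc(C#N)c2)n1OC`: 9130 nM
Compound 2 `CCOC(=O)c1c(C)nc(-c2cccc(C#N)c2)n1OCc1ccc(Br)cc1`: 24600 nM
Compound 3 `CCOC(=O)c1c(C)nc(-c2cccc(C#N)c2)n1OCc1ccc(C(=O)OC)cc1`: 9470 nM

In a functional assay on a cell-free system (plasma, Oryctolagus cuniculus) for inhibition, with stated times of 5 min, 1 min and 6 min (on this read-out lower numbers stand for stronger inhibition and higher numbers for weaker inhibition), compound 1 stands at the low end of the three numbers; compound 3 lies within the usual scatter of it, and only compound 2 stands clearly apart. Compound 4 `CCOC(=O)c1c(C)nc(-c2cccc(C#N)c2)n1OCc1ccc(C#N)cc1` differs from compound 1 by 4-cyanophenyl in place of hydrogen on a saturated chain carbon bound to an oxygen on an aromatic ring. Two measured steps make the same kind of change at the same place: a 2.7-fold higher number from compound 1 to compound 2 (0.43 log units; beyond the scatter) and a 1.0-fold higher number from compound 1 to compound 3 (0.02 log units; within the scatter). Neither brought a lower number, so for compound 4 an unchanged or modestly higher number is expected in this assay, estimated as a 1.3-fold higher number from compound 1 to compound 4 (0.10 log units; within the scatter). Compound 4 is therefore expected to give about 11500 nM, with a likely range from 5000 nM to 26000 nM.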

Compound 4, half-maximal inhibitory concentration: 4240 nM
Compound 4: middle estimate off by 2.7-fold (0.43 log units), on the high side; the measured number lies below the stated range.
By their numbers in this assay, from the lowest: compound 4; then compounds 1 and 3 (each within the scatter of the next); then compound 2.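

For the compounds shown here, with compound 4, adding a substituted phenyl at this saturated chain carbon lowers the number in this assay for the first time (a 2.2-fold lower number from compound 1 to compound 4 (0.33 log units; beyond the scatter)). The group on the added ring clearly matters, since cyano compares well with both methoxycarbonyl (a 2.2-fold lower number from compound 3 to compound 4 (0.35 log units; beyond the scatter)) and bromo (a 5.8-fold lower number from compound 2 to compound 4 (0.76 log units; beyond the scatter)). No measurement here explains why cyano gives the lowest number of the three.

On these data alone, whether an amine or a carboxylic acid on that ring would lower the number further remains open. So does the effect of a longer chain between the oxygen and the ring.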